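Working notes on the trimethoxyphenyl series, compound 4

This account rests on a few compounds, and the source may have more. Where it says the series, first, only, none or still open, it means among the compounds named here.

Measured so far:
compound 1 `COc1cc(C(=O)/C=C/c2cc(-c3cc(OC)c(OC)c(OC)c3)n3nc(-c4ccccc4)cc3n2)cc(OC)c1OC` gives 24300 nM in a functional assay on MDA-MB-231 cells (Homo sapiens) for antiproliferative activity, read by MTT assay, with a stated time of 24 h; a higher number here means a weaker inhibitor, a lower number a stronger inhibitor
compound 2 `COc1cc(-c2cc(/C=C/C(=O)c3ccc(C)cc3)nc3cc(-c4ccccc4)nn23)cc(OC)c1OC` gives 23900 nM in this assay
compound 3 `COc1ccc(/C=C/C(=O)c2cc(-c3cc(OC)c(OC)c(OC)c3)n3nc(-c4ccccc4)cc3n2)cc1` gives 16500 nM in this assay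

Compound 3 holds the lowest of the three numbers in this assay, but its nearest neighbour is compound 2 at a 1.4-fold lower number from compound 2 to compound 3 (0.16 log units; within the scatter), and compound 1 sits only a little further off; all three values lie within the scatter of one another, so no order among them can be claimed.

Compound 4 `COc1cc(-c2cc(/C=C/C(=O)c3ccc(Cl)cc3)nc3cc(-c4ccccc4)nn23)cc(OC)c1OC` differs from compound 3 by 2-((4-chlorophenyl)carbonyl)ethenyl in place of (2-(4-methoxyphenyl)ethenyl)carbonyl on an aromatic carbon. Within the data shown here, two measured steps bear on this. The change on the aryl attached to the carbonyl carbon, a 1.0-fold lower number from compound 1 to compound 2 (0.01 log units; within the scatter), was flat. The change of orientation of the enone together with the para substituent, a 1.4-fold lower number from compound 2 to compound 3 (0.16 log units; within the scatter), was also within the scatter. Compound 4 combines the enone orientation of compound 2 with a 4-chlorophenyl on the carbonyl carbon, so no step beyond the scatter is expected; the expected step is a 1.3-fold higher number from compound 3 to compound 4 (0.10 log units; within the scatter). Compound 4 is estimated at 21000 nM in this assay, with a range of 9000 nM to 48000 nM.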

Compound 4, half-maximal inhibitory concentration: 32500 nM
The estimate for compound 4 lay 1.5-fold (0.19 log units) below the measured number; measured number inside the range.
By their numbers in this assay, from the lowest: compounds 3, 2, 1 and 4 (each within the scatter of the next).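

In this assay, chloro in place of methyl on an aromatic carbon gives a 1.4-fold higher number from compound 2 to compound 4 (0.13 log units; within the scatter), and a change of the aryl group on the carbonyl carbon gives a 1.3-fold higher number from compound 1 to compound 4 (0.13 log units; within the scatter), so three different aryl groups on the carbonyl carbon now sit within the scatter of one another. Among these compounds, the exchange of (2-(4-methoxyphenyl)ethenyl)carbonyl for 2-((4-chlorophenyl)carbonyl)ethenyl on the aromatic carbon gives a 2.0-fold higher number from compound 3 to compound 4 (0.29 log units; within the scatter), which also stays within the scatter, so neither this change nor this position separates the series so far. No evidence is available to explain these numbers.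

The compounds shown leave open how the two enone orientations compare with one aryl group held fixed. Also open, as far as these compounds go, is whether an amine or a carboxylic acid on the aryl group at the carbonyl carbon would give a step beyond the scatter.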